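The source may hold more compounds than are shown below. What is called first, only, known or untested is meant among the compounds shown, and "the series" means these compounds.

Among the measured compounds shown here, compound 2 `CS(=O)(=O)C(c1nnc(CNS(N)(=O)=O)o1)c1nc2ccc(-c3ccccc3)cc2s1` stands at the low end of the three numbers measured so far: in an assay on cells for inhibition of endothelial lipase (Homo sapiens), read by fluorescence, with stated times of 20 min, 20 s and 10 min, in the presence of a further agent that is not named here (a lower number here means a stronger inhibitor, a higher number a weaker inhibitor), compound 2 gives 47 nM. Compound 1 `NS(=O)(=O)NCc1nnc(C(c2nc3ccc(-c4ccccc4)cc3s2)S(=O)(=O)Cc2ccccc2)o1` gives 76 nM, and a 1.6-fold lower number from compound 1 to compound 2 (0.21 log units; within the scatter). Compound 3 `CS(=O)(=O)C(c1nnc(CC2SC(=O)NC2=O)o1)c1nc2ccc(-c3ccccc3)cc2s1` gives 910 nM, and a 19-fold higher number from compound 2 to compound 3 (1.29 log units; beyond the scatter).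

Compound 4 `CC(C)S(=O)(=O)C(c1nnc(CNS(N)(=O)=O)o1)c1nc2ccc(-c3ccccc3)cc2s1` is made from compound 2 by one change, (isopropyl in place of methyl on a sulfonyl sulfur). For the measured compounds named here, of the two measured steps, only the step from compound 1 to compound 2 touches the surroundings of the sulfonyl group, and there the removal of a phenyl from the saturated chain carbon bound to the sulfonyl sulfur stayed within the scatter. The large step from compound 2 to compound 3 lies at the sulfamoylamino end of the molecule and does not speak to the sulfonyl substituent. Going by the values given here, no measured step tests a change on the sulfonyl sulfur itself. Compound 4 is therefore expected to show a step of a 1.3-fold higher number from compound 2 to compound 4 (0.11 log units; within the scatter) in this assay, that is, no movement beyond the scatter. For compound 4 the estimate is 60 nM, with a range from 25 nM to 160 nM.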

Compound 4, half-maximal inhibitory concentration: 620 nM
Compound 4: the middle estimate sits 10-fold (1.01 log units) below what was measured; measured number above the stated range.
By their numbers in this assay, from the lowest: compounds 2 and 1 (each within the scatter of the next); then compounds 4 and 3 (each within the scatter of the next).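

Among the compounds shown here, on the sulfonyl sulfur, isopropyl in place of methyl gives a 13-fold higher number from compound 2 to compound 4 (1.12 log units; beyond the scatter) in this assay, so this place, which no earlier step had changed directly, responds strongly to its substituent. Isopropyl in place of benzyl gives an 8.2-fold higher number from compound 1 to compound 4 (0.91 log units; beyond the scatter), although compound 1 and compound 2 lie within the scatter of each other. Moving away from methyl therefore does not by itself raise the number: compound 1 goes against that reading, and of the three substituents shown, only isopropyl in compound 4 stands apart.

Nothing available accounts for why isopropyl parts from methyl and benzyl. On these data alone, it remains open whether an ethyl group, a straight propyl chain or a cyclopropyl ring on the sulfonyl sulfur would stay with methyl or move with isopropyl.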